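Swapping Hydroxy for Amino on Two Imidazole Phenols

The source may report more compounds than this note shows. Statements on the series, on what has been measured and on what is new or still open speak of the compounds shown alone.

Four small compounds share a pattern of a six-membered carbon ring carrying an imidazole and, on the carbon ring, either a hydroxy or an amino group. Compound 1, `Cn1cncc1-c1ccccc1O`, carries the hydroxy group; in an assay on cells for inhibition of Indoleamine 2,3-dioxygenase 1 (Homo sapiens), read by HPLC, with a stated time of 20 min (a higher number here means a weaker inhibitor, a lower number a stronger inhibitor), compound 1 gives 38000 nM. Compound 2, `Cn1cncc1-c1ccccc1N`, differs from compound 1 by amino in place of hydroxy on an aromatic carbon and in this assay compound 2 gives 1700000 nM. That single swap made a large step: a 45-fold higher number from compound 1 to compound 2 (1.65 log units; beyond the scatter).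

Compound 3, `Oc1ccccc1-n1ccnc1`, has a different core from compound 1; the difference between the two cores is not broken down here. In this assay compound 3 gives 16000 nM, the lowest number of the three measured and beyond the scatter from both compound 1 and compound 2.

Compound 4, `Nc1ccccc1-n1ccnc1`, has not been measured. It differs from compound 3 by amino in place of hydroxy on an aromatic carbon. This is the same kind of change as from compound 1 to compound 2, though not the same in every detail: around the place of the change, compound 3 has the group "ortho to a group of 5 heavy atoms", while compound 1 has it "ortho to a group of 6 heavy atoms".

For compound 4 the expectation is a weakening of similar size, a 38-fold higher number from compound 3 to compound 4 (1.57 log units; beyond the scatter), because the same kind of change gave a 45-fold higher number from compound 1 to compound 2 (1.65 log units; beyond the scatter). Compound 4 is therefore estimated at about 600000 nM, most likely between 120000 nM and 2500000 nM.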

Compound 4, half-maximal inhibitory concentration: 1300000 nM
For compound 4 the middle estimate is 2.2-fold (0.34 log units) below the measured one, within the range that was stated.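

In this assay, putting amino in place of hydroxy on an aromatic carbon again produced a large weakening, this time on the core of compound 3 (an 81-fold higher number from compound 3 to compound 4 (1.91 log units; beyond the scatter)). Set beside the earlier step, the two results cannot be told apart in size: the same change on two cores in this assay, a 45-fold higher number (1.65 log units; beyond the scatter) from compound 1 to compound 2 and an 81-fold higher number (1.91 log units; beyond the scatter) from compound 3 to compound 4, 1.8-fold (0.26 log units) apart, within the scatter of two such steps. This shows that the swap carried over from the core of compound 1 to the core of compound 3 with the same direction and a similar size, so the first step was a useful guide to the second, but two pairs of compounds do not make a general rule, and these numbers do not explain why the amino compounds give higher numbers or show how the swap would behave on any other core.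

The compounds shown leave open how other groups at this same place on the carbon ring, such as methoxy, a fluorine atom or a carboxylic acid, would compare with hydroxy and amino. They also leave open whether the swap would cost as much if a methyl group or a longer chain were added elsewhere on the carbon ring.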